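Swapping the benzyl substituent on a pyrazole amide core

A few compounds are considered here, and "the series" means these few. Any claim that something is new, unique, unknown or untested is made for them only; others in the source may bear on it.

Compound 1, `CC1(C)c2[nH]nc(NC(=O)c3ccccc3)c2CN1Cc1cccc(C#N)c1`, is one of two measured compounds in this set. In an assay on Sf21 cells for inhibition of high affinity nerve growth factor receptor (Homo sapiens), read by HTRF, with a stated time of 30 min, in the presence of a further agent that is not named here (on this read-out higher numbers stand for weaker inhibition and lower numbers for stronger inhibition), compound 1 gives 980 nM, the lowest of the two numbers. Its nearest neighbour is compound 2, `CC1(C)c2[nH]nc(NC(=O)c3ccccc3)c2CN1Cc1ccc(F)cc1F`, which in this assay gives 2320 nM, a change described as a 2.4-fold higher number from compound 1 to compound 2 (0.37 log units; beyond the scatter). Compound 3, `CC1(C)c2[nH]nc(NC(=O)c3ccccc3)c2CN1Cc1c(F)cccc1F`, has not yet been measured. It differs from compound 1 in one place only: 2,6-difluorophenyl in place of 3-cyanophenyl on a saturated chain carbon bound to an amine nitrogen in a ring. For the measured compounds named here, the one measured step that bears on this change is the one from compound 1 to compound 2, where a difluorophenyl also replaced the 3-cyanophenyl and the number rose modestly, beyond the scatter. Since the 2,6-difluorophenyl of compound 3 is likewise a difluorophenyl, a rise of similar size is expected, though the different placement of the two fluorines leaves room for a larger or smaller shift. The expected step is a 2.6-fold higher number from compound 1 to compound 3 (0.41 log units; beyond the scatter). For compound 3 in this assay the estimate is 2500 nM, with a range from 1000 nM to 6500 nM.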

Compound 3, half-maximal inhibitory concentration: 520 nM
Estimate against measurement, compound 3: 4.8-fold (0.68 log units) above; measured number below the stated range.
By their numbers in this assay, from the lowest: compounds 3 and 1 (each within the scatter of the next); then compound 2.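

The placement of the two fluorines matters at this position: in this assay, going from the 2,4-difluorophenyl to the 2,6-difluorophenyl gives a 4.5-fold lower number from compound 2 to compound 3 (0.65 log units; beyond the scatter), so two groups with the same ring and the same substituents are not interchangeable here. The replacement of 3-cyanophenyl by 2,6-difluorophenyl gives a 1.9-fold lower number from compound 1 to compound 3 (0.28 log units; within the scatter), which lies within the scatter, so in this pair the nitrile can be exchanged for two fluorines with no clear change in the number, and the higher number seen with compound 2 cannot be put down simply to the loss of the nitrile. Nothing measured here accounts for why the placement of the fluorines makes this difference.

The compounds shown leave open how an unsubstituted benzyl, or a benzyl carrying a single fluorine, would compare with these three, and so whether either fluorine of compound 3 contributes at all. They also leave open what a longer chain, such as phenethyl, or a methoxy group on the ring would do at this same place on the shared core.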